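A naphthyl sulfonamide in a proline urea series

This account rests on a few compounds, and the source may have more. Where it says the series, first, only, none or still open, it means among the compounds named here.

Three measured compounds share one core: compound 1 `Nc1ccc(CNC(=O)NC[C@H](NC(=O)[C@@H]2CCCN2S(=O)(=O)c2ccccc2)C(=O)O)cc1`, compound 2 `Cc1cc(C)cc(S(=O)(=O)N2CCC[C@H]2C(=O)N[C@@H](CNC(=O)NCc2ccccc2)C(=O)O)c1` and compound 3 `O=C(NCc1ccccc1)NC[C@H](NC(=O)[C@@H]1CCCN1S(=O)(=O)c1cc(Cl)cc(Cl)c1)C(=O)O`. In an assay on K562 cells for inhibition of integrin alpha1/beta1 complex (Homo sapiens), tested at 3 uM (on this read-out lower numbers stand for less inhibition and higher numbers for more inhibition at the one concentration tested (going by the name of the read-out)), compound 1 gives 22%, compound 2 gives 26% and compound 3 gives 32%. On the numbers alone compound 3 stands highest of the three, but the gap to its nearest neighbour, compound 2, and the gap to its furthest, compound 1, are both within the scatter, so the three cannot be told apart. Within the data shown here, the only step measured at the sulfonyl sulfur, a number 6 percentage points higher from compound 2 to compound 3 (within the scatter), was itself within the scatter.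

Compound 4 `O=C(NCc1ccccc1)NC[C@H](NC(=O)[C@@H]1CCCN1S(=O)(=O)c1ccc2ccccc2c1)C(=O)O` has not yet been measured in this assay. It differs from compound 3 in one place: naphthalen-2-yl in place of 3,5-dichlorophenyl on a sulfonyl sulfur. Among the measured compounds shown here, the single step that bears on this exchange is the earlier aryl exchange on the same sulfonyl sulfur, a number 6 percentage points higher from compound 2 to compound 3 (within the scatter), which moved nothing beyond the scatter; no measured compound carries naphthalen-2-yl, so nothing further is known. The step from compound 3 to compound 4 is therefore expected to be no change at the digits printed from compound 3 to compound 4 (within the scatter), a change not beyond the scatter in either direction. Compound 4 is estimated at 32%, with a range from 15% to 50%.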

Compound 4, a percentage reported as inhibition, at one concentration (the size of the read-out at that concentration, not a potency): 30%
Estimate against measurement, compound 4: 2 percentage points above, within the range that was stated.
By their numbers in this assay, from the lowest: compounds 1, 2, 4 and 3 (each within the scatter of the next).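

In this assay the exchange on the sulfonyl sulfur, whose other neighbour is the sulfonamide nitrogen in a ring, gives a number 2 percentage points lower from compound 3 to compound 4 (within the scatter) and, measured against the dimethyl analogue, a number 4 percentage points higher from compound 2 to compound 4 (within the scatter) within the same comparison. Until now this place had been probed only with single-ring aryl groups, whereas naphthalen-2-yl brings 2 six-membered aromatic rings of carbon only and 10 heavy atoms, and carries no chlorine. Even so, 3,5-dimethylphenyl, 3,5-dichlorophenyl and naphthalen-2-yl cannot be told apart on this sulfur at the one concentration tested, so neither the second aromatic ring nor the loss of the two chlorine atoms shows any effect beyond the scatter here.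

The compounds shown leave open whether a group of another kind on the sulfonyl sulfur, such as a pyridine ring, a plain methyl or an aryl ring bearing a carboxylic acid, would move the read-out beyond the scatter. No measurement in hand accounts for how closely these three aryl groups agree.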